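Replacing a methyl with 2-(2-methoxyethoxy)ethoxy

This account rests on a few compounds, and the source may have more. Where it says the series, first, only, none or still open, it means among the compounds named here.

Going by the values given here, in an ADME assay on RAW264.7 cells (Mus musculus) for cytotoxicity, read by MTT assay, with a stated time of 24 h (a higher number here means that more compound is tolerated, a lower number that less compound is tolerated), compound 1 `CC/C=C\C[C@H]1C(=O)C=C[C@H]1CC(=O)OCCC` gives 35 uM, the lowest of the three numbers measured so far. Compound 2 `CC/C=C\C[C@H]1C(=O)C=C[C@H]1CC(=O)Oc1ccccc1OC` gives 161 uM, and compound 3 `CC/C=C\C[C@H]1C(=O)C=C[C@H]1CC(=O)OCCOCCOCCO` gives 162 uM. Both of these numbers lie beyond the scatter from the number of compound 1. Compound 4 `CC/C=C\C[C@H]1C(=O)C=C[C@H]1CC(=O)OCCOCCOCCOC` has not yet been measured. It keeps the core of compound 1 and carries 2-(2-methoxyethoxy)ethoxy in place of methyl on a saturated chain carbon, two bonds along the chain from an oxygen next to a carbonyl group.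

The closest evidence is a single modest step, a 4.6-fold higher number from compound 1 to compound 3 (0.67 log units; beyond the scatter), which puts 2-(2-hydroxyethoxy)ethoxy at that same place. Among the compounds with values here, the names of the two entering groups differ only in hydroxy against methoxy, but no measurement yet shows what that difference does on its own. Compound 2 carries a different kind of group, so it offers no direct guide. A rise of similar size is therefore expected, resting on this one step alone. The estimated step is a 4.3-fold higher number from compound 1 to compound 4 (0.63 log units; beyond the scatter). For compound 4 the estimated value is 150 uM, with an expected range of 70 uM to 320 uM.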

Compound 4, half-maximal toxic concentration: 163 uM
Estimate against measurement, compound 4: 1.1-fold (0.04 log units) below; the measured number falls inside the stated range.
By their numbers in this assay, from the lowest: compound 1; then compounds 2, 3 and 4 (each within the scatter of the next).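

In this assay, 2-(2-methoxyethoxy)ethoxy in place of methyl on a saturated chain carbon, two bonds along the chain from an oxygen next to a carbonyl group, gives a 4.7-fold higher number from compound 1 to compound 4 (0.67 log units; beyond the scatter). This means that a step of this size at this place is now seen with two groups rather than one. Going by these compounds alone, the new comparison also isolates something the earlier compounds could not: methyl in place of hydrogen on an oxygen on a saturated carbon gives a 1.0-fold higher number from compound 3 to compound 4 (0.00 log units; within the scatter), so the two numbers cannot be told apart, and for this pair the hydrogen on that oxygen is not needed for the higher number seen against compound 1.

The compounds shown offer no measurement that explains why either group is tolerated at a higher concentration than the methyl-bearing compound 1. They also leave open whether the same step would appear with a shorter or longer chain of this type, or with an amine or a carboxylic acid in place of the methoxy of compound 4.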